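Replacing One Aromatic Group of Compound 2

This account rests on a few compounds, and the source may have more. Where it says the series, first, only, none or still open, it means among the compounds named here.

- compound 1 `CCN(CC)c1cc(NC(=O)NNc2cc(-c3ccc(F)cc3)c3cnn(C)c3n2)cc(Cl)n1`: 37000 nM
- compound 2 `Cn1ncc2c(-c3ccc(F)cc3)cc(NNC(=O)Nc3cc(Cl)nc(OCCF)c3)nc21`: 29300 nM

In a functional assay on SW620/5-FU cells (Homo sapiens) for cytotoxicity, read by MTT assay, with a stated time of 48 h, in the presence of a further agent that is not named here (a lower number here means that less compound is needed, a higher number that more compound is needed for the effect), compound 2 gives 29300 nM, a value that cannot be told apart from that of compound 1. Compound 3 `Cn1ncc2c(-c3ccc(F)cc3)cc(NNC(=O)Nc3cc(F)cc(F)c3)nc21` has 3,5-difluorophenyl in place of 2-chloro-6-(2-fluoroethoxy)pyridin-4-yl on an amide-type nitrogen. Going by the values given here, the only measured step that bears on this is a 1.3-fold lower number from compound 1 to compound 2 (0.10 log units; within the scatter). It changed one group on the ring that now leaves as a whole, so it is a loose guide, and the new aromatic group has not been measured in these compounds. No change beyond the scatter is therefore expected in this assay, and no direction is favoured. The expected step is a 1.1-fold lower number from compound 2 to compound 3 (0.04 log units; within the scatter). Compound 3 is estimated at 27000 nM, with an expected range of 10000 nM to 70000 nM.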

Compound 3, half-maximal effective concentration: 47400 nM
Estimate against measurement, compound 3: 1.8-fold (0.24 log units) below; measured number inside the range.
By their numbers in this assay, from the lowest: compounds 2, 1 and 3 (each within the scatter of the next).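

In this assay, going by these compounds alone, replacing the whole 2-chloro-6-(2-fluoroethoxy)pyridin-4-yl group on the amide-type nitrogen with 3,5-difluorophenyl gives a 1.6-fold higher number from compound 2 to compound 3 (0.21 log units; within the scatter) even though the earlier step changed only one group on that ring. So, in this pair, exchanging the entire aromatic group, including its ring nitrogen, chlorine and 2-fluoroethoxy chain, does not move the number beyond the usual scatter. No measurement is available that could explain this result.

Because these parts leave together, the pair cannot show what each one contributes alone. From the compounds shown here alone, it also remains open whether a different kind of group at this place, such as a ring carrying an amine or a carboxylic acid, would shift the number beyond the scatter.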